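The compounds below may be only part of what the source reports. "The series", "measured", "known", "first", "only" and "open" are said of these compounds alone.

Compound 2 `CCCCCCCCc1cn(C(c2ccccc2)c2cc3cc(Br)ccc3nc2OC)nn1` gives the lower of the two measured numbers in an ADME assay on PC-3 cells (Homo sapiens) for cytotoxicity, read by sulforhodamine B assay, with a stated time of 48 h, tested at 10 uM (on this read-out higher numbers stand for more inhibition at the one concentration tested (going by the name of the read-out) and lower numbers for less inhibition), where compound 2 gives 2.27%. Within the data shown here, its only measured neighbour is compound 1 `COc1nc2ccc(Br)cc2cc1C(c1ccccc1)n1cc(-c2ccc(OC(F)(F)F)cc2)nn1`, which in this assay gives 21.6%; the one measured step, octyl in place of 4-(trifluoromethoxy)phenyl on an aromatic carbon, runs a number 19.3 percentage points lower from compound 1 to compound 2 (beyond the scatter).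

Compound 3 `COc1nc2ccc(Br)cc2cc1C(c1ccccc1)n1cc(CCO)nn1` is built from compound 2 by a change on the same chain: hydroxy in place of hexyl on a saturated chain carbon, two bonds along the chain from an aromatic carbon. Read one bond further out, this means the octyl chain becomes 2-hydroxyethyl.

Among the measured compounds shown here, no measured step shows a chain being shortened or a hydroxy entering, so the only guidance is that swapping the group at this aromatic carbon once moved the read-out modestly, and compound 2 already sits near the bottom of the scale, where little room remains for a fall. For compound 3 the step is therefore expected to be small, a number 2.7 percentage points higher from compound 2 to compound 3 (within the scatter), with no clear direction beyond the scatter. Compound 3 is estimated to give 5% in this assay, within -8% to 20%.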

Compound 3, a percentage reported as inhibition, at one concentration (the size of the read-out at that concentration, not a potency): 15.5%
The estimate for compound 3 lay 10.5 percentage points below the measured number, within the range that was stated.
By their numbers in this assay, from the lowest: compound 2; then compounds 3 and 1 (each within the scatter of the next).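

In this assay the group on this aromatic carbon no longer has to be swapped from ring to chain for the number to move: changing only the chain, octyl to 2-hydroxyethyl, gives a number 13.2 percentage points higher from compound 2 to compound 3 (beyond the scatter). Against the 4-(trifluoromethoxy)phenyl group of compound 1, the same 2-hydroxyethyl chain gives a number 6.1 percentage points lower from compound 1 to compound 3 (within the scatter), so among these three compounds only the octyl chain of compound 2 stands apart, and an aromatic ring at this place is not needed to keep the number at the level of compound 1. Nothing available explains why the octyl chain and the 2-hydroxyethyl chain differ in this way.

This single change shortens the chain and brings in a hydroxy at the same time, so the step cannot be assigned to either alone; a plain ethyl group and an octyl chain ending in hydroxy would pull the two apart. On these data alone, it also remains open whether the hydroxy itself counts, which a methoxy, an amine or a carboxylic acid at the end of the same short chain would test.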